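Swapping bromo for chloro on a fluorinated ring

The compounds below may be only part of what the source reports. "The series", "measured", "known", "first", "only" and "open" are said of these compounds alone.

Of the compounds shown here, three sharing one core have been measured in an assay on HeLa cells for inhibition of Indoleamine 2,3-dioxygenase 1 (Homo sapiens), read by spectrophotometry, with a stated time of 24 h; a lower number here means that less compound is needed, a higher number that more compound is needed for the effect. Compound 1 `CC(=O)Nc1ccc(S(=O)(=O)NNc2ccc(Cl)cc2)cc1` gives 142 nM. Compound 2 `CC(=O)Nc1ccc(S(=O)(=O)NNc2ccc(Br)cc2)cc1` gives 85 nM. Compound 3 `CC(=O)Nc1ccc(S(=O)(=O)NNc2ccc(F)c(Br)c2)cc1` gives 2490 nM, which stands well apart from both others. The difference between the core of compound 3 and that of compound 2 is not broken down here.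

Compound 2 and compound 1 differ by chloro in place of bromo on an aromatic carbon, and this change gave a 1.7-fold higher number from compound 2 to compound 1 (0.22 log units; within the scatter). Compound 4 `CC(=O)Nc1ccc(S(=O)(=O)NNc2ccc(F)c(Cl)c2)cc1`, not yet measured, differs from compound 3 by chloro in place of bromo on an aromatic carbon. This is the same kind of change, but its surroundings differ: in compound 1 the chloro sits para to a large group, while in compound 4 it sits ortho to a fluoro group and meta to a large group.

Because the earlier step of a 1.7-fold higher number from compound 2 to compound 1 (0.22 log units; within the scatter) stayed within the scatter, a similarly small step is expected here, a 1.4-fold higher number from compound 3 to compound 4 (0.15 log units; within the scatter). Compound 4 is therefore estimated at 3500 nM, with a likely range from 1400 nM to 9000 nM.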

Compound 4, half-maximal effective concentration: 2590 nM
Compound 4: the middle estimate sits 1.4-fold (0.13 log units) above what was measured; the range from low to high includes it.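

In this assay, chloro in place of bromo on an aromatic carbon gave a 1.0-fold higher number from compound 3 to compound 4 (0.02 log units; within the scatter). Set beside the earlier case, the change looks alike on both cores, with two small steps whose gap is no larger than repeated measurements would produce: the same change on two cores in this assay, a 1.7-fold higher number (0.22 log units; within the scatter) from compound 2 to compound 1 and a 1.0-fold higher number (0.02 log units; within the scatter) from compound 3 to compound 4, 1.6-fold (0.21 log units) apart, within the scatter of two such steps. Among the compounds shown here, on these two cores, then, the swap can be carried from one to the other with no clear effect on the number, but this rests on only two pairs and does not show that it would hold on a different core, or for any swap other than these two halogens.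

The compounds shown leave open whether a different kind of group in place of the halogen, such as an amine, a nitrile or a carboxylic acid, would be tolerated as well. They also leave open how the number would respond if the fluoro group of compound 3 and compound 4 were exchanged for a methyl group.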